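A Methoxy Group on the Anilino Ring of Compound 1

A few compounds are considered here, and "the series" means these few. Any claim that something is new, unique, unknown or untested is made for them only; others in the source may bear on it.

Compound 1, `Cc1nc(SCC(=O)Nc2nc(-c3ccc(Cl)cc3)cs2)n(Nc2ccccc2)c1C`: in a functional assay on U-251 cells (Homo sapiens) for antiproliferative activity, read by sulforhodamine B assay, with a stated time of 48 h (a lower number here means a stronger inhibitor of growth, a higher number a weaker inhibitor of growth), compound 1 gives 3130 nM.
Compound 2, `Cc1ccc(Nn2c(SCC(=O)Nc3nc(-c4ccccc4)cs3)nc(C)c2C)cc1`: in this assay compound 2 gives 4500 nM.

Of the compounds shown here, two with a shared core have been measured. Compound 1 carries a chlorine on the phenyl of the thiazole and a plain anilino group on the core; compound 2 carries an unsubstituted phenyl on the thiazole and a methyl on the anilino ring. The two numbers sit within the scatter of each other, so neither compound can be said to inhibit growth more strongly than the other, and compound 1 simply marks the point from which the next step is taken.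

Compound 3, `COc1ccc(Nn2c(SCC(=O)Nc3nc(-c4ccc(Cl)cc4)cs3)nc(C)c2C)cc1`, keeps the chlorophenyl thiazole of compound 1 and differs from it in one place: methoxy in place of hydrogen on an aromatic carbon. Going by the values given here, no measured pair shows this change, so the size of the step is open. Among the compounds with values here, with no such step to lean on, the expectation for the step from compound 1 to compound 3 in this assay is one of no clear direction and of a size not beyond the scatter, a 1.0-fold lower number from compound 1 to compound 3 (0.02 log units; within the scatter). Compound 3 is accordingly expected to give about 3000 nM, between 1200 nM and 8000 nM.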

Compound 3, concentration for 50% growth inhibition: 4030 nM
Compound 3: the middle estimate sits 1.3-fold (0.13 log units) below what was measured; low and high end bracket the measured number.
By their numbers in this assay, from the lowest: compounds 1, 3 and 2 (each within the scatter of the next).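

The anilino ring now has a step of its own in one place: with methoxy in place of hydrogen on an aromatic carbon, para to a large group, this assay gives a 1.3-fold higher number from compound 1 to compound 3 (0.11 log units; within the scatter). This position therefore accepts the methoxy, with its 2 heavy atoms and 1 hydrogen-bond acceptor, without a difference in growth inhibition that can be told from the scatter, something compounds 1 and 2 could not show, as they differ in two places. No separate measurement bears on this result, so the data offer no account of it.

The compounds shown leave open what the methyl on the anilino ring of compound 2 does on its own, and whether methoxy would behave the same way with the unsubstituted phenyl on the thiazole. Also open, from the compounds shown here alone, is what an amine, a carboxylic acid or a longer chain such as ethoxy would do on this same aromatic carbon, and whether any group there can move the number beyond the scatter.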